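Bromines and a hydroxyl replace methoxy groups on an aryl hydrazone

This account rests on a few compounds, and the source may have more. Where it says the series, first, only, none or still open, it means among the compounds named here.

The three measured compounds, tested in a functional assay on MKN-45 cells (Homo sapiens) for cytotoxicity, read by MTT assay, with a stated time of 72 h (a lower number here means a stronger inhibitor, a higher number a weaker inhibitor), are:

Compound 1 `COc1ccc(/C=N/NC(=O)Nc2ccc(Oc3ccnc(-c4nncn4CCN(C)C)c3)c(F)c2)c(OC)c1`: 1680 nM
Compound 2 `CN(C)CCn1cnnc1-c1cc(Oc2ccc(NC(=O)N/N=C/c3ccc(O)c(O)c3)cc2F)ccn1`: 3240 nM
Compound 3 `CN(C)CCn1cnnc1-c1cc(Oc2ccc(NC(=O)N/N=C/c3cccc(Cl)c3Cl)cc2F)ccn1`: 51 nM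

Compound 1 stands second highest of the three numbers. Its nearest neighbour is compound 2, reached by a 1.9-fold higher number from compound 1 to compound 2 (0.29 log units; within the scatter); its furthest is compound 3, reached by a 33-fold lower number from compound 1 to compound 3 (1.52 log units; beyond the scatter). The gap between compounds 2 and 3, a 64-fold lower number from compound 2 to compound 3 (1.80 log units; beyond the scatter), points the same way.

Compound 4 `CN(C)CCn1cnnc1-c1cc(Oc2ccc(NC(=O)N/N=C/c3cc(Br)c(O)c(Br)c3)cc2F)ccn1` is not yet measured. It differs from compound 1 in one place: 3,5-dibromo-4-hydroxyphenyl in place of 2,4-dimethoxyphenyl on a carbon with a double bond to nitrogen. Within the data shown here, two measured steps bear on this change. Entering chlorines on the aryl ring gave the large drop seen in a 33-fold lower number from compound 1 to compound 3 (1.52 log units; beyond the scatter), while entering hydroxyls gave the small shift seen in a 1.9-fold higher number from compound 1 to compound 2 (0.29 log units; within the scatter). Compound 4 carries both halogens and a hydroxyl, so the two precedents pull in different directions, with the halogen precedent being by far the larger. The expected outcome is therefore a lower number in this assay than for compound 1, of moderate size, as the step of a 4.2-fold lower number from compound 1 to compound 4 (0.62 log units; beyond the scatter) expresses. Compound 4 is estimated at 400 nM, within a range from 100 nM to 2500 nM.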

Compound 4, half-maximal inhibitory concentration: 4320 nM
Compound 4: middle estimate off by 11-fold (1.03 log units), on the low side; measured number above the stated range.
By their numbers in this assay, from the lowest: compound 3; then compounds 1, 2 and 4 (each within the scatter of the next, the first and the last beyond it).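

Two halogens on the ring are not enough to give a low number in this assay: 3,5-dibromo-4-hydroxyphenyl in place of 2,3-dichlorophenyl gives an 85-fold higher number from compound 3 to compound 4 (1.93 log units; beyond the scatter) and so loses nearly all of what compound 3 had gained. Compound 4 instead sits with the ring carrying two hydroxyls, since a 1.3-fold higher number from compound 2 to compound 4 (0.12 log units; within the scatter) leaves the two indistinguishable, and even the 2,4-dimethoxyphenyl ring does better, as a 2.6-fold higher number from compound 1 to compound 4 (0.41 log units; beyond the scatter) shows in a modest step. Among these four compounds, the three whose aryl ring carries oxygen all give high numbers, and only compound 3, whose ring has chlorines and no oxygen, stands apart.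

No measurement shown here explains this gap between the two halogen-bearing rings.
Going by these compounds, it remains open whether the hydroxyl of compound 4 or the kind and placing of its halogens sets its number, which a ring with the two bromines and no hydroxyl could help separate, and how an amine or a carboxylic acid on this ring would read.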